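Benzyloxy for Oxolanyl on the Amide Carbonyl

This account rests on a few compounds, and the source may have more. Where it says the series, first, only, none or still open, it means among the compounds named here.

Measured compounds:
Compound 1 `CNC(=O)c1cc(C)n(Cc2cc(Cl)ccc2OCc2ccccc2)n1` in a physicochemical assay for lipophilicity, at pH 7.4; on this read-out lower numbers stand for lower lipophilicity and higher numbers for higher lipophilicity: > 3.7
Compound 2 `Cc1cc(NC(=O)C2CCCO2)nn1Cc1cc(Cl)ccc1OCc1ccccc1` in this assay: > 3.7

Compound 1 reaches only a limit of this assay, not a number. Compound 2 likewise reaches only a limit of this assay. Within the data shown here, the step that the two limits leave unreadable from compound 1 to compound 2, which swaps ((oxolan-2-yl)carbonyl)amino in for methylcarbamoyl on an aromatic carbon, therefore cannot be read in size or direction, and the only evidence available is the limit of > 3.7 in this assay, at which 2 of the 2 values shown sit. Compound 2 thus stands at the limit of this assay, with no number below or above it to anchor a trend.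

Compound 3 `Cc1cc(NC(=O)OCc2ccccc2)nn1Cc1cc(Cl)ccc1OCc1ccccc1` differs from compound 2 by benzyloxy in place of oxolan-2-yl on a carbonyl carbon whose other neighbour is an amide-type nitrogen. Among the measured compounds shown here, no measured step bears on this change, since the one step known is itself unreadable. With compound 2 already at the limit, compound 3 is expected to sit at or beyond that same limit, an expected step that the limit leaves unreadable from compound 2 to compound 3. The estimate for compound 3 in this assay is 4.8, with a range from 4 to 5.6.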

Compound 3, distribution coefficient: 3.1
Compound 3: the middle estimate sits 1.70 log units above what was measured; the measured number lies below the stated range.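

Compound 3 is the one compound here that falls inside the readable range of this assay, which gives the carbonyl position its only measured anchor: the limit of > 3.7 in this assay, at which 2 of the 3 values shown sit.

Benzyloxy in place of oxolan-2-yl on a carbonyl carbon whose other neighbour is an amide-type nitrogen gives a number at least 0.60 log units lower from compound 2 to compound 3 (beyond the scatter), although benzyloxy is the group with more heavy atoms and the two groups count the same hydrogen-bond donors and acceptors. Taking (benzyloxycarbonyl)amino in place of methylcarbamoyl on an aromatic carbon gives a number at least 0.60 log units lower from compound 1 to compound 3 (beyond the scatter), so both readable steps point the same way, while the step between the two compounds that sit at the limit still cannot be read.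

As far as these compounds go, the full size of these two steps stays open, as compound 1 and compound 2 each reach only a limit and not a number. Also open, from the compounds shown here alone, is where a primary amine or a carboxylic acid, carried on a longer chain in place of benzyloxy on the same carbonyl carbon, would fall in this assay.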